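Return from pyridin-4-yl to a fluorophenyl on the ring nitrogen

The compounds below may be only part of what the source reports. "The series", "measured", "known", "first", "only" and "open" are said of these compounds alone.

Compound 1 `Nc1scc(CN2CCN(c3ccc(F)cc3Cl)CC2)c1C(=O)c1ccc(Cl)cc1` gives -70% in a functional assay on CHO cells with adenosine receptor A1 (Homo sapiens) as the target, read by cAMP accumulation and immunoassay, with a stated time of 6 min, tested at 10 uM; a higher number here means a weaker effect of the compound at the concentration tested, a lower number a stronger effect. For the measured compounds named here, compound 2 `Nc1scc(CN2CCN(c3ccncc3)CC2)c1C(=O)c1ccc(Cl)cc1` gives -15%, the highest of the two numbers; the single measured step, a number 55 percentage points higher from compound 1 to compound 2 (beyond the scatter), is large and beyond the scatter. Compound 3 `Nc1scc(CN2CCN(c3ccccc3F)CC2)c1C(=O)c1ccc(Cl)cc1` differs from compound 2 by 2-fluorophenyl in place of pyridin-4-yl on an amine nitrogen in a ring. This is the reverse direction of the measured swap, a fluorophenyl entering where pyridin-4-yl leaves, so a large fall in this assay is expected. Compound 3 is therefore estimated at -55%, with a range of -80% to -25%. The expected step is a number 40 percentage points lower from compound 2 to compound 3 (beyond the scatter).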

Compound 3, a percentage reported as activity, at one concentration (the size of the read-out at that concentration, not a potency): -15%
For compound 3 the middle estimate is 40 percentage points below the measured one; measured number outside the range, above it.
By their numbers in this assay, from the lowest: compound 1; then compounds 2 and 3 (each within the scatter of the next).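

Swapping pyridin-4-yl for 2-fluorophenyl on the ring nitrogen leaves this assay unmoved, with no change at the digits printed from compound 2 to compound 3 (within the scatter), so a carbon-only aromatic ring with fluorine does not by itself reproduce the reading of compound 1. The large difference instead appears between the two halogenated phenyl groups, with a number 55 percentage points higher from compound 1 to compound 3 (beyond the scatter), and thus depends on how 2-chloro-4-fluorophenyl differs from 2-fluorophenyl. No evidence at hand accounts for either step.

Open, going by these compounds, is how 2-chlorophenyl and 4-fluorophenyl would read at this position, which would help separate the contributions of the chlorine and the fluorine. Also open, on these data alone, is whether a saturated group such as cyclohexyl would read like either halogenated phenyl group.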